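Amide-nitrogen substituent change in a benzimidazole carboxamide series

The source may hold more compounds than are shown below. What is called first, only, known or untested is meant among the compounds shown, and "the series" means these compounds.

Three compounds of the series have a reading in an ADME assay on Vero cells (Chlorocebus sabaeus) for cytotoxicity; on this read-out lower numbers stand for higher toxicity in this test and higher numbers for lower toxicity in this test. Compound 1 `O=C(Nc1ccccc1F)c1cccc2[nH]c(-c3ccncc3)nc12` gives 111 uM, compound 2 `COc1ccc(-c2nc3c(C(=O)NCCCO)cccc3[nH]2)c(OC)c1OC` gives 40 uM, and compound 3 `COc1ccc(-c2nc3c(C(=O)Nc4c[nH]cn4)cccc3[nH]2)cc1OC` gives 306 uM. Compound 3 stands highest of the three; its nearest neighbour is compound 1, whose number is lower by a margin beyond the scatter, and compound 2 lies furthest below it, also beyond the scatter. Among the measured compounds shown here, these compounds differ from one another in more than one place, so no single step between them can be read off.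

Compound 4 `COc1ccc(-c2nc3c(C(=O)Nc4ncccc4O)cccc3[nH]2)cc1OC` is not yet measured in this assay. It differs from compound 3 only in 3-hydroxypyridin-2-yl in place of 1H-imidazol-4-yl on an amide-type nitrogen. For the measured compounds named here, there is no measured pair that isolates a change of this kind, so the size of the step rests on the general spread of the series alone.

The expectation is that compound 4 stays close to compound 3, with a step from compound 3 to compound 4 of a 1.4-fold lower number from compound 3 to compound 4 (0.14 log units; within the scatter), not beyond the scatter. The estimate for compound 4 is 220 uM, within a range from 80 uM to 500 uM.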

Compound 4, half-maximal toxic concentration: 164 uM
Beside the measured number, compound 4's estimate is 1.3-fold (0.13 log units) above it; low and high end bracket the measured number.
By their numbers in this assay, from the lowest: compound 2; then compounds 1, 4 and 3 (each within the scatter of the next, the first and the last beyond it).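

In this assay the series now has its first step that isolates the substituent on the amide-type nitrogen: 3-hydroxypyridin-2-yl in place of 1H-imidazol-4-yl gives a 1.9-fold lower number from compound 3 to compound 4 (0.27 log units; within the scatter) with the rest of the structure unchanged. At this position, one five-membered aromatic ring can thus be exchanged for a six-membered aromatic ring with a hydroxy group, and the step in this assay does not go beyond the scatter, so the reading of compound 3 does not depend on 1H-imidazol-4-yl as the only possible substituent among these two compounds. Nothing available explains why the two substituents read so similarly.

Compounds 1 and 2 differ from compound 3 and compound 4 in more than one place, so steps to them cannot be read, and the effect of the amide substituent alone remains known from this single pair. Also open, going by these compounds, is whether the same holds for quite different groups on this nitrogen, such as an aminoethyl chain or a chain ending in a carboxylic acid, and whether the hydroxy group of 3-hydroxypyridin-2-yl contributes anything beside the plain pyridine ring.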